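Aryl sulfone variation on the shared core: dichloro analogue

The source may report more compounds than this note shows. Statements on the series, on what has been measured and on what is new or still open speak of the compounds shown alone.

Compound 3 `Cc1ccc(S(=O)(=O)c2cnc3cc(F)ccc3c2N2CCC(C)CC2)cc1Cl` gives 93% in an assay on isolated protein for displacement of a labelled ligand from metabotropic glutamate receptor 5 (Homo sapiens), with a stated time of 60 min, tested at 1 uM (on this read-out lower numbers stand for less inhibition and higher numbers for more inhibition at the one concentration tested (going by the name of the read-out)), and stands highest of the three numbers recorded, though only by a margin within the scatter over compound 1 `COc1ccc(S(=O)(=O)c2cnc3cc(F)ccc3c2N2CCC(C)CC2)cc1`, which in this assay gives 90%. Compound 2 `CC1CCN(c2c(S(=O)(=O)c3ccc(F)cc3)cnc3cc(F)ccc23)CC1`, with 74.5% in this assay, sits beyond the scatter below both.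

The next compound, compound 4 `CC1CCN(c2c(S(=O)(=O)c3cc(Cl)cc(Cl)c3)cnc3cc(F)ccc23)CC1`, differs from compound 3 in one place: 3,5-dichlorophenyl in place of 3-chloro-4-methylphenyl on a sulfonyl sulfur. Within the data shown here, two measured steps concern the same sulfonyl sulfur. One is a number 18.5 percentage points higher from compound 2 to compound 3 (beyond the scatter), the other a number 3 percentage points higher from compound 1 to compound 3 (within the scatter). Exchanging the aryl group on the sulfonyl sulfur has thus moved this assay by a modest amount at most, and the two aryl groups carrying a chlorine sit at the top of the set. Compound 3 already lies close to the upper end of the read-out, leaving little room for a rise.

For compound 4 the expectation is therefore a step of a number 5 percentage points lower from compound 3 to compound 4 (within the scatter), within the scatter, and an estimated value of 88% in this assay, with a range from 75% to 97%.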

Compound 4, a percentage reported as inhibition, at one concentration (the size of the read-out at that concentration, not a potency): 87%
Compound 4: middle estimate off by 1 percentage points, on the high side; measured number inside the range.
By their numbers in this assay, from the lowest: compound 2; then compounds 4, 1 and 3 (each within the scatter of the next).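

In this assay, the aryl group on the sulfonyl sulfur now carries two chlorines and no methyl, and this gives a number 6 percentage points lower from compound 3 to compound 4 (within the scatter) and also a number 3 percentage points lower from compound 1 to compound 4 (within the scatter) so that 3,5-dichlorophenyl, 3-chloro-4-methylphenyl and 4-methoxyphenyl cannot be told apart at this position. Among these compounds, only 4-fluorophenyl stands apart from these three, with a number 12.5 percentage points higher from compound 2 to compound 4 (beyond the scatter) as a second step of this kind alongside the one to compound 3. Nothing measured on hand accounts for these differences.

As far as these compounds go, a carboxylic acid or an amine on the aryl group, or a cyclohexyl group in place of the aryl group on the sulfonyl sulfur, remains open. From the compounds shown here alone, the order among compounds 1, 3 and 4 also stays open, as a single-concentration read-out leaves these three unresolved.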